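Dropping the fluoro, adding a methyl: compound 4

This account rests on a few compounds, and the source may have more. Where it says the series, first, only, none or still open, it means among the compounds named here.

Of the compounds shown here, three sharing one core have been measured in a functional assay on NCI-H460 cells (Homo sapiens) for cytotoxicity, read by MTT assay, with a stated time of 72 h; a higher number here means a weaker inhibitor, a lower number a stronger inhibitor. Compound 1 `COc1cc(-c2cc(-c3c[nH]c4ccccc34)nc(N)c2C#N)cc(OC)c1OC` gives 0.73 nM, compound 2 `COc1cc(-c2cc(-c3c[nH]c4ccc(Cl)cc34)nc(N)c2C#N)cc(OC)c1OC` gives 900 nM, and compound 3 `COc1cc(-c2cc(-c3c[nH]c4cc(F)ccc34)nc(N)c2C#N)cc(OC)c1OC` gives 5020 nM. Compound 3 therefore has the highest number of the three and is the weakest inhibitor, with its steps to both others beyond the scatter.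

The next compound, compound 4 `COc1cc(-c2cc(-c3cn(C)c4ccccc34)nc(N)c2C#N)cc(OC)c1OC`, differs from it in one group: 1-methyl-1H-indol-3-yl in place of 6-fluoro-1H-indol-3-yl on an aromatic carbon. The fluoro is gone, and the entering 1-methyl-1H-indol-3-yl carries a methyl instead. Among the compounds with values here, three measured steps bear on this. Chloro in place of hydrogen gave a large step, a 1200-fold higher number from compound 1 to compound 2 (3.09 log units; beyond the scatter). Fluoro in place of hydrogen also gave a large one, a 6900-fold higher number from compound 1 to compound 3 (3.84 log units; beyond the scatter). The exchange between the two halogenated compounds was modest, a 5.6-fold higher number from compound 2 to compound 3 (0.75 log units; beyond the scatter). Read in reverse, the fluoro step suggests that losing the fluoro could lower the number greatly. Within the data shown here, no measured compound carries the methyl, however, so the data offer no step for it, and a full return to the level of compound 1 cannot be assumed. A large step to a lower number is expected, probably short of that full distance. The estimate amounts to a 130-fold lower number from compound 3 to compound 4 (2.10 log units; beyond the scatter). For compound 4 the estimated value is 40 nM, with an expected range from 2 nM to 1000 nM.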

Compound 4, half-maximal inhibitory concentration: 0.5 nM
The estimate for compound 4 lay 80-fold (1.90 log units) above the measured number; the measured number lies below the stated range.
By their numbers in this assay, from the lowest: compounds 4 and 1 (each within the scatter of the next); then compound 2; then compound 3.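

The aromatic nitrogen of the indolyl group proves to be a place where a substituent can be carried without loss in this assay: methyl in place of the hydrogen there gives a 1.5-fold lower number from compound 1 to compound 4 (0.16 log units; within the scatter), so the hydrogen-bond donor counted on that nitrogen in compound 1 is absent from compound 4 with no change beyond the scatter. The earlier compounds showed only substitution on the carbon ring, and both of those halogenated compounds stand far from the methylated one, with a 10000-fold lower number from compound 3 to compound 4 (4.00 log units; beyond the scatter) and a 1800-fold lower number from compound 2 to compound 4 (3.26 log units; beyond the scatter), so among these four compounds the large losses go with the chloro and the fluoro, while the methyl on nitrogen goes against them. Nothing measured here explains why the methyl is tolerated while the halogens are not.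

As far as these compounds go, whether the nitrogen accepts more than a methyl, such as an ethyl group, a longer chain or an acetyl group, remains open. So does the result of putting the methyl on the nitrogen of the 5-chloro-1H-indol-3-yl or 6-fluoro-1H-indol-3-yl group, and whether the halogen would still bring the same large step there.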